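Replacing 3,4-dichlorophenyl with 2,4-dimethoxyphenyl

The source may hold more compounds than are shown below. What is called first, only, known or untested is meant among the compounds shown, and "the series" means these compounds.

Among the measured compounds shown here, in a functional assay on MCF cells (Homo sapiens) for antiproliferative activity, with a stated time of 72 h (a higher number here means a weaker inhibitor, a lower number a stronger inhibitor), compound 2 (`OC[C@H]1O[C@@H](n2cnc3c(NCc4ccc(Cl)c(Cl)c4)ncnc32)[C@H](O)[C@@H]1O`) gives 88800 nM as the only exact number so far. Compound 1 (`OC[C@H]1O[C@@H](n2cnc3c(NCc4ccc(Br)cc4)ncnc32)[C@H](O)[C@@H]1O`) stands at > 166000 nM as a limit and not a number. Compound 3 (`COc1ccc(CNc2ncnc3c2ncn3[C@@H]2O[C@H](CO)[C@@H](O)[C@H]2O)c(OC)c1`) carries 2,4-dimethoxyphenyl in place of 3,4-dichlorophenyl on a saturated chain carbon bound to a nitrogen on an aromatic ring. For the measured compounds named here, the only measured step bearing on this is an at least 1.8-fold lower number from compound 1 to compound 2 (0.27 log units; that floor lies within the scatter) and its floor offers no size to carry over. No step beyond the scatter is therefore expected, the estimate being a 1.2-fold higher number from compound 2 to compound 3 (0.09 log units; within the scatter) in this assay overall. Compound 3 is expected near 110000 nM (estimated range 45000 nM to 250000 nM).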

Compound 3, half-maximal inhibitory concentration: > 166000 nM
Compound 3: a limit, no number; the forecaster's own chance of this, stated with the estimate: 35%; at least 1.5-fold (0.17 log units) between middle value and limit.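

In this assay, compound 3 gives > 166000 nM, which is a limit and not a number. The change to 2,4-dimethoxyphenyl brings an at least 1.8-fold higher number from compound 2 to compound 3 (0.27 log units; that floor lies within the scatter), so this change does not establish a difference. With a second group at this place reaching the limit, only 3,4-dichlorophenyl has given an exact number: the limit of > 166000 nM in this assay, at which 2 of the 3 values shown sit.

The step from compound 1 to compound 3 cannot be read, since both values are limits. From the compounds shown here alone, whether an amine or a carboxylic acid on this aromatic ring, or a longer chain at this place, would give an exact number remains open.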